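The compounds below may be only part of what the source reports. "The series", "measured", "known", "first", "only" and "open" are said of these compounds alone.

Compound 2 `Cc1cccc(Cn2c(CN3CCN(C(=O)CC(C)C)CC3)nc3ccccc32)c1` gives 71.4% in an assay on isolated protein for inhibition of aldehyde dehydrogenase 1A1 (Homo sapiens), read by spectrophotometry, tested at 10 uM (a lower number here means less inhibition, a higher number more inhibition at the concentration tested (going by the name of the read-out)), the highest of the three measured values; compound 3 `O=C(C1CC1)N1CCN(Cc2nc3ccccc3n2Cc2ccc(F)cc2)CC1` gives 32.7% and compound 1 `Cc1cccc(Cn2c(CN3CCN(C(=O)c4cccnc4)CC3)nc3ccccc32)c1` gives 24.5%. Going by the values given here, the only measured change at the carbonyl carbon, a number 46.9 percentage points higher from compound 1 to compound 2 (beyond the scatter), exchanged pyridin-3-yl for isobutyl and was large. Compound 4 `Cc1cccc(Cn2c(CN3CCN(C(=O)C4CCCCC4)CC3)nc3ccccc32)c1` differs from compound 2 by cyclohexyl in place of isobutyl on a carbonyl carbon; both groups are made of carbon only, so that measured step does not bear directly on this one. Among the compounds with values here, with no measured step between two such groups, compound 4 is expected to remain close to compound 2, within the scatter, as a number 1.4 percentage points lower from compound 2 to compound 4 (within the scatter). The estimate for compound 4 is therefore 70%, between 52% and 88%.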

Compound 4, a percentage reported as inhibition, at one concentration (the size of the read-out at that concentration, not a potency): 31.9%
Beside the measured number, compound 4's estimate is 38.1 percentage points above it; the whole stated range lies above it.
By their numbers in this assay, from the lowest: compounds 1, 4 and 3 (each within the scatter of the next); then compound 2.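

Two groups made of carbon only proved not to be interchangeable on the carbonyl carbon in this assay: cyclohexyl in place of isobutyl gave a number 39.5 percentage points lower from compound 2 to compound 4 (beyond the scatter). Cyclohexyl in place of pyridin-3-yl gave a number 7.4 percentage points higher from compound 1 to compound 4 (within the scatter), so among these three groups only isobutyl stands apart, and the aromatic and non-aromatic rings cannot be told apart here. No evidence at hand accounts for this. From the compounds shown here alone, whether the ring itself or the size of the group matters remains open. A straight butyl chain, a tert-butyl group or a cyclopropyl ring on the same carbonyl carbon would help separate these.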